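Halogen swap on a bis-indolylmethane series, first notes

The compounds below may be only part of what the source reports. "The series", "measured", "known", "first", "only" and "open" are said of these compounds alone.

Compound 1 `O=[N+]([O-])c1ccc2[nH]cc(C(c3ccc(Cl)cc3)c3c[nH]c4ccc([N+](=O)[O-])cc34)c2c1` and compound 2 `O=[N+]([O-])c1ccc2[nH]cc(C(c3ccc(Br)cc3)c3c[nH]c4ccc([N+](=O)[O-])cc34)c2c1` share a core, and compound 2 arises from compound 1 by bromo in place of chloro on an aromatic carbon. In a functional assay on HeLa cells (Homo sapiens) for inhibition, read by MTT assay, with a stated time of 48 h (a lower number here means a stronger inhibitor, a higher number a weaker inhibitor), compound 1 gives only a limit, > 100000 nM. Compound 2 likewise sits at a limit, > 100000 nM. The step that the two limits leave unreadable from compound 1 to compound 2 therefore cannot be read, both values resting at the limit of > 100000 nM in this assay, at which 2 of the 3 values shown sit. Compound 3 `OC[C@H]1O[C@@H](n2cc(C(c3ccc(Cl)cc3)c3cn([C@@H]4O[C@H](CO)[C@@H](O)[C@H](O)[C@H]4O)c4ccc(Br)cc34)c3cc(Br)ccc32)[C@H](O)[C@@H](O)[C@@H]1O` carries a different core; the difference between the two cores is not broken down here. In this assay, among the measured compounds shown here, compound 3 gives 32000 nM, the only number so far. Compound 4 `OC[C@H]1O[C@@H](n2cc(C(c3ccc(Br)cc3)c3cn([C@@H]4O[C@H](CO)[C@@H](O)[C@H](O)[C@H]4O)c4ccc(Br)cc34)c3cc(Br)ccc32)[C@H](O)[C@@H](O)[C@@H]1O` differs from compound 3 by bromo in place of chloro on an aromatic carbon, the same change as from compound 1 to compound 2, at the same place. Because the step that the two limits leave unreadable from compound 1 to compound 2 is unreadable, the expectation for compound 4 rests on the value of compound 3, 32000 nM. The step of a 1.1-fold lower number from compound 3 to compound 4 (0.03 log units; within the scatter) is expected to be small. Compound 4 is thus estimated at 30000 nM, with a range from 12000 nM to 80000 nM.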

Compound 4, half-maximal inhibitory concentration: 27000 nM
Compound 4: the middle estimate sits 1.1-fold (0.05 log units) above what was measured; the range from low to high includes it.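

In this assay, 4-bromophenyl in place of 4-chlorophenyl gives a 1.2-fold lower number from compound 3 to compound 4 (0.07 log units; within the scatter). On this core the swap therefore leaves the read-out within the usual scatter, though this rests on a single pair. Whether the same holds on the core of compound 1 stays unknown, the step there being unreadable with both compounds resting at a limit: the limit of > 100000 nM in this assay, at which 2 of the 4 values shown sit.

Still open, from the compounds shown here alone, is whether another group in place of the halogen on the phenyl ring, such as an amine, a carboxylic acid or a methoxy group, would move the number beyond the scatter in this assay. Also open, going by these compounds, is what separates the two cores, which differ in more than one place.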